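A Methyl Group Added to Compound 2

This account rests on a few compounds, and the source may have more. Where it says the series, first, only, none or still open, it means among the compounds named here.

Compound 1 `COc1cc(NC(=O)NNc2cc(-c3ccccc3)c3cnn(C)c3n2)cc(Cl)n1`: 28700 nM
Compound 2 `Cn1ncc2c(-c3ccccc3)cc(NNC(=O)Nc3cc(Cl)nc(Cl)c3)nc21`: 76900 nM
Compound 3 `CCCc1cc(NNC(=O)Nc2cc(Cl)nc(Cl)c2)nc2c1cnn2C`: 38700 nM

In a functional assay on SW620/5-FU cells (Homo sapiens) for cytotoxicity, read by MTT assay, with a stated time of 48 h, in the presence of a further agent that is not named here (on this read-out lower numbers stand for an effect already at smaller amounts and higher numbers for an effect only at larger amounts of compound), compound 2 gives 76900 nM, the highest of the three numbers. Its distance from the other two compounds differs: a 2.7-fold higher number from compound 1 to compound 2 (0.43 log units; beyond the scatter), whereas a 2.0-fold lower number from compound 2 to compound 3 (0.30 log units; within the scatter).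

Compound 4 `Cc1nn(C)c2nc(NNC(=O)Nc3cc(Cl)nc(Cl)c3)cc(-c3ccccc3)c12` remains to be measured. It differs from compound 2 as follows: methyl in place of hydrogen on an aromatic carbon. In short, this is methyl in place of hydrogen on an aromatic carbon.

Neither measured step changes this carbon, so both bear on the question only indirectly. They show that changes elsewhere, including the much larger exchange in a 2.0-fold lower number from compound 2 to compound 3 (0.30 log units; within the scatter), moved the number only modestly or not beyond the scatter. A step beyond the scatter is therefore not expected in this assay, and no direction is strongly favoured. The expected change is a 1.2-fold lower number from compound 2 to compound 4 (0.07 log units; within the scatter). For compound 4 the estimated value is 65000 nM, with an expected range of 30000 nM to 140000 nM.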

Compound 4, half-maximal effective concentration: 22900 nM
Compound 4: middle estimate off by 2.8-fold (0.45 log units), on the high side; measured number outside the range, below it.
By their numbers in this assay, from the lowest: compounds 4, 1, 3 and 2 (each within the scatter of the next, the first and the last beyond it).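

In this assay, among these compounds, methyl in place of hydrogen gives a 3.4-fold lower number from compound 2 to compound 4 (0.53 log units; beyond the scatter), the first step at this aromatic carbon of the five-membered ring. A single added carbon here therefore moves the number beyond the scatter toward an effect at smaller amounts, whereas the far larger exchange of propyl for phenyl elsewhere gives a 2.0-fold lower number from compound 2 to compound 3 (0.30 log units; within the scatter) and stays within it. Nothing available here explains why this methyl has that effect.

The compounds shown hold only hydrogen and methyl on this carbon, so they leave open how an ethyl group or an amine there would read. They also leave open whether the same methyl would lower the number when the core carries the methoxy group of compound 1 or the propyl group of compound 3.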